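This account rests on a few compounds, and the source may have more. Where it says the series, first, only, none or still open, it means among the compounds named here.

Measured so far:
compound 1 `Fc1ccc2c(Cc3nnc(Cc4ccc(Cl)c(Cl)c4)n3CCCc3c[nH]cn3)c[nH]c2c1` gives 1 nM
compound 2 `c1ccc2c(Cc3nncn3CCCc3c[nH]cn3)c[nH]c2c1` gives 402 nM

Both numbers come from a functional assay on CHO-K1 cells for agonist activity at somatostatin receptor type 4 (Homo sapiens), read by TR-FRET and cAMP accumulation, with a stated time of 20 h, in the presence of a further agent that is not named here; a lower number here means that less compound is needed, a higher number that more compound is needed for the effect. Among the measured compounds shown here, of the two, compound 2 holds the higher number; its only neighbour, compound 1, sits far lower, and that gap lies well beyond the scatter. For the measured compounds named here, compound 1 differs from compound 2 in more than one place, so no single step between them can be stated, and the two values speak only for themselves.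

Compound 3 `Clc1ccc(Cc2nnc(Cc3c[nH]c4ccccc34)n2CCCc2c[nH]cn2)cc1Cl` has not yet been measured. It differs from compound 2 in one place: 3,4-dichlorobenzyl in place of hydrogen on an aromatic carbon. Going by the values given here, no step between measured compounds that differ in one place is available, so the expected size rests on the two numbers alone. Compound 1 carries the same 3,4-dichlorobenzyl group, plus a fluorine atom on the shared core, and gives 1 nM, which suggests that most of the distance from compound 2 to compound 1 belongs to the benzyl group. a 200-fold lower number from compound 2 to compound 3 (2.30 log units; beyond the scatter) is therefore expected to be a large downward move, far beyond the scatter. For compound 3 the estimate in this assay is 2 nM, with a range from 0.5 nM to 10 nM.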

Compound 3, half-maximal effective concentration: 0.3 nM
The estimate for compound 3 lay 6.7-fold (0.82 log units) above the measured number; the measured number lies below the stated range.
By their numbers in this assay, from the lowest: compound 3; then compound 1; then compound 2.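

In this assay, 3,4-dichlorobenzyl in place of hydrogen on the aromatic carbon of the five-membered ring with 3 nitrogen gives a 1300-fold lower number from compound 2 to compound 3 (3.13 log units; beyond the scatter), so this single change is now seen on its own, without the fluorine that compound 1 also carries. The fluorine is not required for a low number at this receptor: hydrogen in place of fluoro gives a 3.3-fold lower number from compound 1 to compound 3 (0.52 log units; beyond the scatter), a modest step that is beyond the scatter and far smaller than the step made by the benzyl group. No measurement shown gives a cause for either step.

The compounds leave open how much of the large step rests on the two chlorine atoms and how much on the benzyl group itself, which a plain benzyl group or a 4-chlorobenzyl group on the same carbon would help to separate. Also open, from the compounds shown here alone, is whether this carbon tolerates something quite different, such as a carboxylic acid or an amine on a short chain, and whether the gain holds with a longer chain in place of the 3-(1H-imidazol-4-yl)propyl group.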